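Swapping the aryl group on the tetrazole of an FAAH inhibitor

The compounds below may be only part of what the source reports. "The series", "measured", "known", "first", "only" and "open" are said of these compounds alone.

Measured so far:
- compound 1, `CCCCCCCCc1ccc(OCC(=O)Cn2nnc(-c3ccccn3)n2)cc1`: 18 nM
- compound 2, `CCCCCCCCc1ccc(OCC(=O)Cn2nnc(-c3ccc(C(=O)O)cc3)n2)cc1`: 90 nM
- compound 3, `CCCCCCCCc1ccc(OCC(=O)Cn2nnnc2-c2cccc(Cl)c2)cc1`: 360 nM

All three were tested in an assay on microsomes from brain for inhibition of Fatty-acid amide hydrolase 1 (Rattus norvegicus), read by fluorescence and HPLC, with a stated time of 60 min; a higher number here means a weaker inhibitor, a lower number a stronger inhibitor. Among the measured compounds shown here, compound 1 gives 18 nM, and the single one-place step, a 5.0-fold higher number from compound 1 to compound 2 (0.70 log units; beyond the scatter), already weakens inhibition. Compound 3 stands at the top of the three numbers with 360 nM, beyond the scatter from compound 2 and further still from compound 1.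

Compound 4, `CCCCCCCCc1ccc(OCC(=O)Cn2nnnc2Cc2ccccc2)cc1`, is not yet measured. It differs from compound 3 in one place: benzyl in place of 3-chlorophenyl on an aromatic carbon. For the measured compounds named here, the only step that has been measured, from compound 1 to compound 2, changes an aryl group that sits at a different position of the core, so it does not bear directly on this change; no measured pair tests a benzyl against a 3-chlorophenyl here. With nothing to anchor the direction, the expectation for compound 4 is a step of about a 1.1-fold higher number from compound 3 to compound 4 (0.05 log units; within the scatter), which is within the scatter around compound 3. Compound 4 is therefore estimated at 400 nM, with a range from 120 nM to 1400 nM.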

Compound 4, half-maximal inhibitory concentration: 320 nM
The estimate for compound 4 lay 1.3-fold (0.10 log units) above the measured number; measured number inside the range.
By their numbers in this assay, from the lowest: compound 1; then compound 2; then compounds 4 and 3 (each within the scatter of the next).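

In this assay, putting benzyl in place of 3-chlorophenyl gives a 1.1-fold lower number from compound 3 to compound 4 (0.05 log units; within the scatter), so the two groups cannot be told apart at this position. Among the compounds shown here, this is the first measured pair that changes this aromatic carbon directly: the chlorine is gone and the ring now hangs on one extra carbon, yet the number stays within the scatter. No measurement here explains why these two groups read alike.

From the compounds shown here alone, both groups carry a six-membered aromatic ring of carbon only, so it remains open whether a group without a ring, such as a methyl or a longer chain, would read the same. Going by these compounds, it also remains open how a chlorine, an amine or a carboxylic acid on the benzyl ring would read.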